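A few compounds are considered here, and "the series" means these few. Any claim that something is new, unique, unknown or untested is made for them only; others in the source may bear on it.

Three compounds of the series have been run in an assay for inhibition of Alpha amylase (Homo sapiens), with a stated time of 10 min; on this read-out higher numbers stand for weaker inhibition and lower numbers for stronger inhibition. Compound 1 `COc1cccc(-c2nc3cc(Cl)ccc3[nH]2)c1Cl` gives 2780 nM. Compound 2 `COc1ccc(-c2nc3cc(Cl)ccc3[nH]2)c(F)c1` gives 2740 nM, and compound 3 `COc1ccc(-c2nc3cc([N+](=O)[O-])ccc3[nH]2)c(F)c1` gives 2750 nM. The difference between the cores of compound 1 and compound 2 is not broken down here. Compound 3 arises from compound 2 by the change (nitro in place of chloro on an aromatic carbon), and that change produced a step of a 1.0-fold higher number from compound 2 to compound 3 (0.00 log units; within the scatter). Compound 4 `COc1cccc(-c2nc3cc([N+](=O)[O-])ccc3[nH]2)c1Cl` has not yet been measured; it arises from compound 1 by the same change, (nitro in place of chloro on an aromatic carbon), at the same place. Because the earlier step was a 1.0-fold higher number from compound 2 to compound 3 (0.00 log units; within the scatter), the same size of step is expected from compound 1, a 1.0-fold higher number from compound 1 to compound 4 (0.00 log units; within the scatter), resting on that single prior example. Compound 4 is accordingly estimated in this assay at 2800 nM, with a range from 1400 nM to 5600 nM.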

Compound 4, half-maximal inhibitory concentration: 2780 nM
Estimate against measurement, compound 4: 1.0-fold (0.00 log units) above; low and high end bracket the measured number.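

Nitro in place of chloro on an aromatic carbon gives no change at the digits printed from compound 1 to compound 4 (within the scatter). In this assay, the change carries from one core to the other with no difference beyond the scatter: the same change on two cores in this assay, a 1.0-fold higher number (0.00 log units; within the scatter) from compound 2 to compound 3 and no change at the digits printed (within the scatter) from compound 1 to compound 4, 1.0-fold (0.00 log units) apart, within the scatter of two such steps

Both steps are flat, so this agreement does not test whether a step of real size would carry across cores, and two cores set no rule for the wider series.

Open, from the compounds shown here alone, is whether an amine or a carboxylic acid at the same place would shift the number in this assay. Also open, going by these compounds, is how either chloro or nitro compares with plain hydrogen there.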